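Opening a Ring to a Chain on the Shared Core

This account rests on a few compounds, and the source may have more. Where it says the series, first, only, none or still open, it means among the compounds named here.

Two measured compounds share a core and differ in the group on its ring amide nitrogen. In a physicochemical assay for solubility, read by HPLC, in phosphate buffer, measured as thermodynamic solubility, with a stated time of 24 h, at pH 6.8 (a lower number here means a less soluble compound, a higher number a more soluble compound), compound 1 `C=CC(=O)N1CC[C@H](N2C(=O)N(c3ccccc3)Cc3cnc(Nc4ccc(N5CCN(C)CC5)c(OC)c4)nc32)C1` gives 256 ug/mL. Compound 2 `C=CC(=O)N1CCC[C@@H](N2C(=O)N(Cc3ccccc3)Cc3cnc(Nc4ccc(N5CCN(C)CC5)cc4OC)nc32)C1` gives 142 ug/mL in this assay, a number that sits within the usual scatter of the result for compound 1. Compound 3 `C=CC(=O)NCCN1C(=O)N(Cc2ccccc2)Cc2cnc(Nc3ccc(N4CCN(C)CC4)cc3OC)nc21` carries the change (2-((vinylcarbonyl)amino)ethyl in place of 1-(vinylcarbonyl)piperidin-3-yl on an amide-type nitrogen in a ring). Among the compounds with values here, no measured step exists for such a change here, so the step of a 1.3-fold higher number from compound 2 to compound 3 (0.10 log units; within the scatter) is expected to stay within the scatter, with no clear direction. Compound 3 is therefore estimated at 180 ug/mL, between 70 ug/mL and 450 ug/mL.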

Compound 3, solubility: 96.7 ug/mL
Compound 3: the middle estimate sits 1.9-fold (0.27 log units) above what was measured, and the stated range covers the measured number.
By their numbers in this assay, from the lowest: compounds 3, 2 and 1 (each within the scatter of the next, the first and the last beyond it).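

On the amide-type nitrogen in a ring, 2-((vinylcarbonyl)amino)ethyl in place of 1-(vinylcarbonyl)piperidin-3-yl gives a 1.5-fold lower number from compound 2 to compound 3 (0.17 log units; within the scatter) in this assay for this one pair. At this position, then, the six-membered ring and the defined stereocentre can give way to an open chain carrying a hydrogen-bond donor, and the two numbers still cannot be told apart. Nothing shown here gives a measured reason for this result.

Going by these compounds, whether a longer chain, or a chain ending in an amine, would also stay within the scatter remains open. A single step also cannot show whether this swap would read the same on another core.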